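Swapping a Difluorophenyl for a Pyridinyl: Solubility Outlook

This account rests on a few compounds, and the source may have more. Where it says the series, first, only, none or still open, it means among the compounds named here.

Of the compounds shown here, two have been measured in a physicochemical assay for solubility, read by nephelometry, in phosphate buffer, measured as kinetic solubility, at pH 6.5; a higher number here means a more soluble compound, a lower number a less soluble compound. Compound 1 `CCOC(=O)C1=C(O)/C(=C\c2cc(C)n(-c3ccc(F)cc3)c2C)N=C1C` gives 3.1 ug/mL in this assay. Compound 2 `CCOC(=O)C1=C(C)N/C(=C/c2cc(C)n(-c3ccc(F)cc3F)c2C)C1=O` gives 6.3 ug/mL in this assay, the higher of the two numbers. The gap between the two values lies beyond the usual scatter of repeated measurements, so compound 2 is the more soluble of the pair.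

Compound 3 `CCOC(=O)C1=C(C)N/C(=C/c2cc(C)n(-c3ccncc3)c2C)C1=O` has not yet been measured. It differs from compound 2 in a single place: pyridin-4-yl in place of 2,4-difluorophenyl on an aromatic nitrogen. Among the measured compounds shown here, no pair of measured compounds shows this exchange, so its effect on solubility is not known from the data. The expected step is a 2.5-fold higher number from compound 2 to compound 3 (0.40 log units; beyond the scatter), a moderate rise rather than none. Compound 3 is therefore estimated at 16 ug/mL, within a range from 5 ug/mL to 50 ug/mL.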

Compound 3, solubility: 50 ug/mL
Beside the measured number, compound 3's estimate is 3.1-fold (0.49 log units) below it, within the range that was stated.
By their numbers in this assay, from the lowest: compound 1; then compound 2; then compound 3.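

In this assay, putting pyridin-4-yl in place of 2,4-difluorophenyl on the aromatic nitrogen gives a 7.9-fold higher number from compound 2 to compound 3 (0.90 log units; beyond the scatter). Among the compounds shown here, this is the first direct reading of a change at this position, and it shows that the group held there can move the number well past the ordinary noise of the measurement, with the rest of the molecule unchanged. The exchange is not a single small edit, however: the fluorines leave, a ring nitrogen enters, and the group gains a hydrogen-bond acceptor, so one step cannot separate these parts.

As far as these compounds go, how a plain phenyl ring, or a phenyl ring carrying an amine or a carboxylic acid, would read at this place remains open. Nothing measured here accounts for the size of the step.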